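This account rests on a few compounds, and the source may have more. Where it says the series, first, only, none or still open, it means among the compounds named here.

In an ADME assay on L1210/0 cells (Mus musculus) for cytotoxicity, with a stated time of 48 h (on this read-out lower numbers stand for stronger inhibition and higher numbers for weaker inhibition), compound 1 `O=c1[nH]c(=O)n([C@H]2C[C@H](O)[C@@H](CO)O2)cc1/C=C/I` gives 63900 nM, compound 2 `C=Cc1cn([C@H]2C[C@H](O)[C@@H](CO)O2)c(=O)[nH]c1=O` gives 14200 nM and compound 3 `C=C(Cl)c1cn([C@H]2C[C@H](O)[C@@H](CO)O2)c(=O)[nH]c1=O` gives 1660 nM, the lowest of the three numbers. Compound 4 `O=c1[nH]c(=O)n([C@H]2C[C@H](O)[C@@H](CO)O2)cc1C#CCO` is still unmeasured. It differs from compound 3 by 3-hydroxyprop-1-yn-1-yl in place of 1-chloroethenyl on an aromatic carbon, which puts 3-hydroxyprop-1-yn-1-yl in place of 1-chloroethenyl on an aromatic carbon. Going by the values given here, no measured step involves this incoming group, so the closest evidence is the other exchanges on an aromatic carbon: a 4.5-fold lower number from compound 1 to compound 2 (0.65 log units; beyond the scatter) was modest and a 38-fold lower number from compound 1 to compound 3 (1.59 log units; beyond the scatter) was large. A further modest step, an 8.6-fold lower number from compound 2 to compound 3 (0.93 log units; beyond the scatter), gave compound 3 its lead, so a modest to large step to a higher number is expected in this assay. The expected change is an 11-fold higher number from compound 3 to compound 4 (1.04 log units; beyond the scatter). The estimate for compound 4 is 18000 nM, with an expected range from 3000 nM to 90000 nM.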

Compound 4, half-maximal inhibitory concentration: > 200000 nM
Compound 4: a limit, no number; the forecaster's own chance of this, stated with the estimate: 15%; middle value at least 11-fold (1.04 log units) from the limit.
By their numbers in this assay, from the lowest: compound 3; then compound 2; then compound 1. At a limit, above all of these: compound 4.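

At this position on the aromatic carbon, the assay range extends beyond what the double-bonded chains showed. In this assay, compound 4 gives only a limit, not a number: the limit of > 200000 nM in this assay, at which 1 of the 4 values shown sits. Placing 3-hydroxyprop-1-yn-1-yl here gives an at least 120-fold higher number from compound 3 to compound 4 (2.08 log units; beyond the scatter), an at least 14-fold higher number from compound 2 to compound 4 (1.14 log units; beyond the scatter) and an at least 3.1-fold higher number from compound 1 to compound 4 (0.49 log units; beyond the scatter), so compound 4 sits above all three compounds with double-bonded chains, even the one bearing 2-iodoethenyl.

Still open, from the compounds shown here alone, is whether the triple bond or the chain's hydroxyl goes with this shift. A plain prop-1-yn-1-yl chain or an amine in place of that hydroxyl would separate the two.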